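Working notes: from compound 3 to compound 4

This account rests on a few compounds, and the source may have more. Where it says the series, first, only, none or still open, it means among the compounds named here.

Measured in a functional assay on MCF7 cells (Homo sapiens) for antiproliferative activity (on this read-out lower numbers stand for stronger inhibition and higher numbers for weaker inhibition), so far:
- compound 1 `CC(=O)Oc1ccc(C(=O)Nc2cc3ccc(OCC4CCCN(C)C4)c(C)c3oc2=O)cc1CC=C(C)C`: 1650 nM
- compound 2 `CC(=O)Oc1ccc(C(=O)Nc2cc3ccc(OCCC4CCCCN4)c(C)c3oc2=O)cc1CC=C(C)C`: 710 nM
- compound 3 `CC(C)=CCc1cc(C(=O)Nc2cc3ccc(OCC4CCCN(C)C4)c(C)c3oc2=O)ccc1O`: 2640 nM

Compound 3 stands at 2640 nM and cannot be separated from compound 1 on these numbers, the measured step being a 1.6-fold higher number from compound 1 to compound 3 (0.20 log units; within the scatter). Compound 2 shows a lower number at 710 nM than either of them.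

The next compound is compound 4 `CC(C)=CCc1cc(C(=O)Nc2cc3ccc(OCC4CCN(C)C4)c(C)c3oc2=O)ccc1O`, not yet measured. Its structural change from compound 3 is 1-methylpyrrolidin-3-yl in place of 1-methylpiperidin-3-yl on a saturated chain carbon bound to an oxygen on an aromatic ring.

For the measured compounds named here, only one measured step touches the same place: a 2.3-fold lower number from compound 1 to compound 2 (0.37 log units; beyond the scatter). That step is modest, swaps in a different group and was taken with the acetyl still on the oxygen, so it is only a loose guide to size. The other step, a 1.6-fold higher number from compound 1 to compound 3 (0.20 log units; within the scatter), lies elsewhere on the molecule and says nothing on ring size. Going by the values given here, no measured pair changes ring size alone, so the data give no direction. A shift no larger than the modest step is expected, most likely none beyond the scatter.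

The estimated step is a 1.1-fold lower number from compound 3 to compound 4 (0.04 log units; within the scatter) in this assay. For compound 4 the expected value is 2400 nM, with an estimated range of 1000 nM to 5500 nM.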

Compound 4, half-maximal inhibitory concentration: 1550 nM
Estimate against measurement, compound 4: 1.5-fold (0.19 log units) above; low and high end bracket the measured number.
By their numbers in this assay, from the lowest: compound 2; then compounds 4, 1 and 3 (each within the scatter of the next).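

In this assay, for the compounds shown here, the change from (1-methylpiperidin-3-yl)methoxy to (1-methylpyrrolidin-3-yl)methoxy gives a 1.7-fold lower number from compound 3 to compound 4 (0.23 log units; within the scatter), the first reading of ring size alone at this position. The earlier step at this place, a 2.3-fold lower number from compound 1 to compound 2 (0.37 log units; beyond the scatter), swapped in a different group with the acetyl still on the oxygen, so it could not isolate ring size. With hydrogen on the oxygen, the six-membered and five-membered rings cannot be separated on these numbers, and no measurement of any property of either ring is available to bear on this result.

Still open, as far as these compounds go, is whether this ring-size result holds with acetyl on the oxygen, and whether the step seen with the (piperidin-2-yl)methyl group carries over when hydrogen stands there instead. The compounds shown also leave open how an azetidine ring, a morpholine ring or an open-chain dimethylamino group on the same saturated chain would read out in this assay, so the reach of this flat ring-size result beyond the two N-methyl rings remains undefined.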